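The source may report more compounds than this note shows. Statements on the series, on what has been measured and on what is new or still open speak of the compounds shown alone.

Compound 1 `COc1ccc(C2=C(c3cc(OC)c(OC)c(OC)c3)C(=O)C(OC(C)=O)C2)cc1OC(C)C`: > 100 ug/mL (a limit)
Compound 2 `COc1ccc(C2=C(c3cc(OC)c(OC)c(OC)c3)C(=O)C(O[SiH2]C(C)(C)C)C2)cc1OC(C)C`: 7.1 ug/mL
Compound 3 `COc1ccc(C2=C(c3cc(OC)c(OC)c(OC)c3)CC(O[SiH2]C(C)(C)C)C2=O)cc1[N+](=O)[O-]`: > 100 ug/mL (a limit)

In an ADME assay on HEp-2 cells (Homo sapiens) for cytotoxicity, read by MTT assay, with a stated time of 72 h (on this read-out higher numbers stand for weaker inhibition and lower numbers for stronger inhibition), compound 1 gives > 100 ug/mL, which is a limit and not a number. Compound 1 thus sits at the limit of > 100 ug/mL in this assay, at which 2 of the 3 values shown sit. Only compound 2 has a true number.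

The next compound is compound 4 `COc1ccc(C2=C(c3cc(OC)c(OC)c(OC)c3)C(=O)C(OC(C)=O)C2)cc1O`, which keeps the core of compound 1 and changes one group. The change is hydrogen in place of isopropyl on an oxygen on an aromatic ring, that is, isopropoxy to hydroxy.

For the measured compounds named here, no measured step makes this change. Going by the values given here, the only measured step, an at least 14-fold lower number from compound 1 to compound 2 (1.14 log units; beyond the scatter), is large, but it lies at a different place, on an oxygen on a saturated carbon. It therefore bears on the new change only indirectly, showing that one change to compound 1 can move the number a long way. Its size cannot simply be carried over. From a limit, a measurable shift can only go towards lower numbers, which would mean stronger inhibition, and a modest shift in that direction is expected. Compound 4 may also stay at the limit.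

The estimated step is an at least 2.5-fold lower number from compound 1 to compound 4 (0.39 log units; beyond the scatter). For compound 4, the expected value is 40 ug/mL, with an estimated range of 6 ug/mL to 120 ug/mL.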

Compound 4, half-maximal inhibitory concentration: > 100 ug/mL
Compound 4 gave a limit, no number (the forecaster's own chance of this, stated with the estimate: 45%); at least 2.5-fold (0.39 log units) between middle value and limit.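

Compound 4 stays at the same limit as compound 1, so no step can be read between these two compounds: the limit of > 100 ug/mL in this assay, at which 3 of the 4 values shown sit. The compounds shown leave open whether replacing isopropoxy with hydroxy changes the result in this assay at all, and in which direction any change would run.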